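Replacing methylcarbamoyl with methoxymethyl: a stability estimate

The source may report more compounds than this note shows. Statements on the series, on what has been measured and on what is new or still open speak of the compounds shown alone.

Measured so far in an ADME assay (liver, Mus musculus) for metabolic stability, using microsomes; a higher number here means that the compound lasts longer, a lower number that the compound disappears faster:
- compound 1 `C=CC(=O)Nc1cccc(CNc2nc(Nc3cc(F)c(N4CCN(C(C)=O)CC4)c(F)c3)ncc2Cl)c1`: 0.0567 h
- compound 2 `C=CC(=O)Nc1ccc(CNc2nc(Nc3cnn(C)c3)ncc2Cl)cc1`: 0.0517 h
- compound 3 `C=CC(=O)Nc1ccc(CNc2nc(Nc3cnn(CC(=O)NC)c3)ncc2Cl)cc1`: 0.355 h

Compound 3 stands highest of the three, clearly above both compound 1 and compound 2. Compound 4 `C=CC(=O)Nc1ccc(CNc2nc(Nc3cnn(CCOC)c3)ncc2Cl)cc1` remains unmeasured. It carries methoxymethyl in place of methylcarbamoyl on a saturated chain carbon bound to an aromatic nitrogen. Among the compounds with values here, one measured step bears on this: a 6.9-fold higher number from compound 2 to compound 3 (0.84 log units; beyond the scatter), which brought in methylcarbamoyl in place of hydrogen at that place. Within the data shown here, no measured compound carries methoxymethyl, so that step offers only a rough guide. Part of its gain is expected to be lost, which points to a moderate fall in this assay, smaller than that step. The expected change is a 3.0-fold lower number from compound 3 to compound 4 (0.47 log units; beyond the scatter). Compound 4 is estimated at 0.12 h, within a range of 0.05 h to 0.3 h.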

Compound 4, half-life: 0.0467 h
Compound 4: middle estimate off by 2.6-fold (0.41 log units), on the high side; measured number below the stated range.
By their numbers in this assay, from the lowest: compounds 4, 2 and 1 (each within the scatter of the next); then compound 3.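

In this assay, the gain brought by methylcarbamoyl does not carry over to methoxymethyl on this saturated chain carbon bound to an aromatic nitrogen: there is a 7.6-fold lower number from compound 3 to compound 4 (0.88 log units; beyond the scatter), and a 1.1-fold lower number from compound 2 to compound 4 (0.04 log units; within the scatter). Among the compounds with this pyrazolyl substituent, only the one carrying methylcarbamoyl stands apart, so chain length alone does not separate them. Nothing available explains the difference. The compounds shown leave open whether the amide hydrogen or the carbonyl goes with the higher number. They also leave open how dimethylcarbamoyl, a carboxylic acid or an amine at this place would compare.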